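Replacing 4-methoxyphenyl with thiophen-2-yl

The source may report more compounds than this note shows. Statements on the series, on what has been measured and on what is new or still open speak of the compounds shown alone.

In a functional assay on NCI-H460 cells (Homo sapiens) for inhibition, with a stated time of 72 h (on this read-out higher numbers stand for weaker inhibition and lower numbers for stronger inhibition), compound 2 `COc1ccc(-c2cccc3c2N(S(=O)(=O)c2ccc(OC)cc2)CC3)cc1` gives 302 nM and compound 1 `COc1ccc(S(=O)(=O)N2CCc3cccc(-c4ccc(N(C)C)cc4)c32)cc1` gives 556 nM, so the two stand within the scatter of each other. Compound 3 `COc1ccc(S(=O)(=O)N2CCc3cccc(-c4cccs4)c32)cc1` has thiophen-2-yl in place of 4-methoxyphenyl on an aromatic carbon. Among the compounds with values here, the only measured step, a 1.8-fold lower number from compound 1 to compound 2 (0.27 log units; within the scatter), exchanged dimethylamino for methoxy and stayed within the scatter. Within the data shown here, no measured step covers an exchange of a whole ring, so this is a weak guide. In this assay, among the measured compounds shown here, the expected change is a 1.5-fold higher number from compound 2 to compound 3 (0.17 log units; within the scatter), with no step expected beyond the scatter. The estimated value for compound 3 is 450 nM, with an expected range of 150 nM to 1400 nM.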

Compound 3, half-maximal inhibitory concentration: 229 nM
Compound 3: middle estimate off by 2.0-fold (0.29 log units), on the high side, within the range that was stated.
By their numbers in this assay, from the lowest: compounds 3, 2 and 1 (each within the scatter of the next, the first and the last beyond it).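

In this assay, a five-membered thiophen-2-yl ring can stand at this aromatic carbon in place of 4-methoxyphenyl, with a 1.3-fold lower number from compound 2 to compound 3 (0.12 log units; within the scatter) and so no real change. Set against the 4-(dimethylamino)phenyl group, the same ring gives a 2.4-fold lower number from compound 1 to compound 3 (0.39 log units; beyond the scatter) as the first step in this series beyond the scatter, though a modest one. No measured evidence explains why these numbers fall as they do.

Going by these compounds, whether a non-aromatic ring such as piperidine, or a thiophene carrying a carboxylic acid, would be accepted at this position remains open.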